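A few compounds are considered here, and "the series" means these few. Any claim that something is new, unique, unknown or untested is made for them only; others in the source may bear on it.

Compound 1 `CCCNc1nc(C)nc2c1cnn2-c1ccccc1` and compound 2 `Cc1nc(NC(C)C)c2cnn(-c3ccccc3)c2n1` share a core that carries a small alkylamino group. In a functional assay on G-361 cells (Homo sapiens) for cytotoxicity, read by sulforhodamine B assay (a lower number here means a stronger inhibitor of growth, a higher number a weaker inhibitor of growth), compound 1 gives 36000 nM, and compound 2 gives 32000 nM; the step of a 1.1-fold lower number from compound 1 to compound 2 (0.05 log units; within the scatter). Compound 3 `CCN(CC)c1nc(C)nc2c1cnn2-c1ccccc1` carries a diethylamino group in that place. For compound 3 the result is only a limit of the assay, > 100000 nM. Compound 3 therefore stands at the far end of the three measured values, at the limit (the limit of > 100000 nM in this assay, at which 1 of the 3 values shown sits). The steps of an at least 2.7-fold higher number from compound 1 to compound 3 (0.44 log units; beyond the scatter) and an at least 3.1-fold higher number from compound 2 to compound 3 (0.49 log units; beyond the scatter) both raised the number beyond the scatter. Compound 4 `Cc1nc(NCc2ccccc2)c2cnn(-c3ccccc3)c2n1` differs from compound 3 by benzylamino in place of diethylamino on an aromatic carbon. This change brings back a hydrogen-bond donor on the amino group, the feature that compound 1 and compound 2 have and compound 3 lacks, so a lower number in this assay is expected, of a size like those two steps. The expected step is an at least 3.3-fold lower number from compound 3 to compound 4 (0.52 log units; beyond the scatter). Compound 4 is estimated at 30000 nM, in a range from 8000 nM to 100000 nM.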

Compound 4, concentration for 50% growth inhibition: > 100000 nM
Compound 4 ended at the assay's limit; the forecaster's own chance of this, stated with the estimate: 20%; at least 3.3-fold (0.52 log units) between middle value and limit.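

Compound 1 and compound 2 carry a hydrogen-bond donor on the amino group, and benzylamino carries one too, yet in this assay compound 4 gives only a limit of the assay, > 100000 nM. Among these compounds, then, a donor at this place does not by itself go with a lower number, and benzylamino sits apart from the two small alkylamino groups, with an at least 3.1-fold higher number from compound 2 to compound 4 (0.49 log units; beyond the scatter) and an at least 2.7-fold higher number from compound 1 to compound 4 (0.44 log units; beyond the scatter). The step between compound 3 and compound 4 cannot be read, because both stand at the same limit: the limit of > 100000 nM in this assay, at which 2 of the 4 values shown sit.

The compounds shown leave open whether the aromatic ring of benzylamino matters or simply a larger group, and a cyclohexylmethylamino or butylamino group at this place would help tell these apart. Going by these compounds, the true values of compound 3 and compound 4 also remain unknown.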